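The source may hold more compounds than are shown below. What is called first, only, known or untested is meant among the compounds shown, and "the series" means these compounds.

Within the data shown here, in a functional assay on K562 cells (Homo sapiens) for inhibition, read by sulforhodamine B assay, with a stated time of 48 h, tested at 1 uM (on this read-out higher numbers stand for a weaker effect at the one concentration tested and lower numbers for a stronger effect), compound 3 `COc1cc(Cl)cc(-c2nn(-c3cccc(NC(=O)Nc4ccc(Cl)c(C(F)(F)F)c4)c3)cc2-c2ccncc2)c1` gives 35%, the lowest of the three numbers measured so far, which on this read-out means the strongest effect. For comparison, compound 1 `O=C(Nc1cccc(-n2cc(-c3ccncc3)c(-c3cc(O)cc(Cl)c3)n2)c1)Nc1ccc(Cl)c(C(F)(F)F)c1` gives 55% and compound 2 `O=C(Nc1cccc(-n2cc(-c3ccncc3)c(-c3cc(O)cc(Cl)c3)n2)c1)Nc1ccc(Cl)c(Cl)c1` gives 83%. Compound 3 differs from compound 1 by a methyl in place of hydrogen on an oxygen on an aromatic ring, a change that gave a number 20 percentage points lower from compound 1 to compound 3 (beyond the scatter).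

Compound 4 `COc1cc(Cl)cc(-c2nn(-c3cccc(NC(=O)Nc4ccc(Cl)c(Cl)c4)c3)cc2-c2ccncc2)c1` is obtained from compound 3 by a single change: chloro in place of trifluoromethyl on an aromatic carbon. The same exchange has already been seen once, between compound 1 and compound 2, where it gave a number 28 percentage points higher from compound 1 to compound 2 (beyond the scatter). That step is the one that bears directly on the present case, since the rest of the molecule is otherwise unchanged in both pairs.

On that basis a step of similar size and direction is expected, namely a number 28 percentage points higher from compound 3 to compound 4 (beyond the scatter). Compound 4 is therefore estimated to give 63%, most likely between 45% and 80%.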

Compound 4, a percentage reported as activity, at one concentration (the size of the read-out at that concentration, not a potency): 67%
Compound 4: middle estimate off by 4 percentage points, on the low side; measured number inside the range.
By their numbers in this assay, from the lowest: compound 3; then compound 1; then compound 4; then compound 2.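

The exchange of trifluoromethyl for chloro now appears on a second core, the one with a methyl on the oxygen, with a number 32 percentage points higher from compound 3 to compound 4 (beyond the scatter), and its two readings agree: the same change on two cores in this assay, a number 28 percentage points higher (beyond the scatter) from compound 1 to compound 2 and a number 32 percentage points higher (beyond the scatter) from compound 3 to compound 4, 4 percentage points apart, within the scatter of two such steps The methyl on the oxygen can likewise now be read with the 3,4-dichlorophenyl group in place, with a number 16 percentage points lower from compound 2 to compound 4 (beyond the scatter), and these two readings also agree: the same change on two cores in this assay, a number 20 percentage points lower (beyond the scatter) from compound 1 to compound 3 and a number 16 percentage points lower (beyond the scatter) from compound 2 to compound 4, 4 percentage points apart, within the scatter of two such steps Across these four compounds in this assay, each change therefore keeps its direction and a similar size whichever form the other place takes.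

Going by these compounds, only trifluoromethyl and chloro appear at this position, so it remains open how a bromo, a methyl or a nitrile group there would read. With one concentration per compound, these numbers show only how each change shifts the effect at that concentration and leave open how it would read at any other concentration.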